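This account rests on a few compounds, and the source may have more. Where it says the series, first, only, none or still open, it means among the compounds named here.

Compound 1 `Cc1cccc(C(=O)N2CCCC(C(=O)Nc3ccc(Cl)cc3)C2)c1`: 0%
Compound 2 `COc1cccc(C(=O)N2CCCC(C(=O)Nc3ccc(Cl)cc3)C2)c1`: 0%
Compound 3 `Cc1nc(-c2cccc(C(=O)N3CCCC(C(=O)Nc4ccc(Cl)cc4)C3)c2)cs1`: 1%

In an ADME assay on PC-3 cells (Homo sapiens) for cytotoxicity, read by WST assay, tested at 100 uM (on this read-out lower numbers stand for less inhibition and higher numbers for more inhibition at the one concentration tested (going by the name of the read-out)), compound 3 sits together with compound 1 and compound 2, all three within the scatter of one another, so none of them stands apart. Compound 4 `CS(=O)(=O)c1cccc(C(=O)N2CCCC(C(=O)Nc3ccc(Cl)cc3)C2)c1` differs from compound 3 by methylsulfonyl in place of 2-methyl-1,3-thiazol-4-yl on an aromatic carbon. The two measured steps that touch this aromatic carbon, a number 1 percentage points higher from compound 1 to compound 3 (within the scatter) and a number 1 percentage points higher from compound 2 to compound 3 (within the scatter), were both within the scatter, so exchanging the substituent at this position has so far not moved the read-out. The step is therefore expected to be a number 1 percentage points higher from compound 3 to compound 4 (within the scatter), that is, none beyond the scatter. Compound 4 is expected to give 2%, with a range from 0% to 10%.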

Compound 4, a percentage reported as inhibition, at one concentration (the size of the read-out at that concentration, not a potency): 2%
Compound 4: middle estimate and measured number agree at the digits printed, within the range that was stated.
By their numbers in this assay, from the lowest: compounds 1, 2, 3 and 4 (each within the scatter of the next).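

In this assay the methylsulfonyl group, with its double bonds outside aromatic rings and no ring, still leaves the read-out within the scatter: the steps are a number 1 percentage points higher from compound 3 to compound 4 (within the scatter) and a number 2 percentage points higher from compound 2 to compound 4 (within the scatter) and also a number 2 percentage points higher from compound 1 to compound 4 (within the scatter) in this comparison. All four groups shown on this aromatic carbon, meta to a large group, thus give numbers within the scatter of one another. Nothing measured here gives a reason for this.

As far as these compounds go, whether an amine or a carboxylic acid on this carbon would also leave the read-out unmoved stays open. So does the effect of a change elsewhere on the shared core.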